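Two Methoxy Groups Added to a Piperazine Aryl Ring

The source may hold more compounds than are shown below. What is called first, only, known or untested is meant among the compounds shown, and "the series" means these compounds.

Of the compounds shown here, three have been measured in a functional assay for antagonist activity at Alpha-1A adrenergic receptor (Oryctolagus cuniculus); a higher number here means weaker binding, a lower number tighter binding. Compound 1 `COc1ccccc1N1CCN(CCCNc2ccc(C(=O)N(C)C)cn2)CC1` gives 25.1 nM, compound 2 `COc1ccccc1N1CCN(CCCNc2ccccc2C(=O)c2ccccc2)CC1` gives 31.6 nM, and compound 3 `CN(C)C(=O)c1cccnc1NCCCN1CCN(c2ccccc2)CC1` gives 6.31 nM. Compound 3 therefore has the lowest number of the three; its gaps to compound 1, the nearest, and to compound 2 both lie beyond the usual scatter, so compound 3 binds most tightly here.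

Compound 4 `COc1ccc(N2CCN(CCCNc3ncccc3C(=O)N(C)C)CC2)c(OC)c1` is not yet measured. It differs from compound 3 in one place: 2,4-dimethoxyphenyl in place of phenyl on an amine nitrogen in a ring. Among the measured compounds shown here, no measured pair differs only in this way, so the step cannot be read directly from the numbers. A modest weakening is expected, a 2.4-fold higher number from compound 3 to compound 4 (0.38 log units; beyond the scatter), because compound 1, whose ring also carries methoxy, gives 25.1 nM while differing elsewhere too. Compound 4 is estimated at 15 nM, within a range from 5 nM to 50 nM.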

Compound 4, dissociation constant: 31.6 nM
The estimate for compound 4 lay 2.1-fold (0.32 log units) below the measured number; low and high end bracket the measured number.
By their numbers in this assay, from the lowest: compound 3; then compounds 1, 2 and 4 (each within the scatter of the next).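

In this assay, the change from phenyl to 2,4-dimethoxyphenyl on the ring amine nitrogen gives a 5.0-fold higher number from compound 3 to compound 4 (0.70 log units; beyond the scatter) with the rest of the molecule unchanged. Among the compounds shown here, this is the first direct reading at this position, and it shows that adding the two methoxy groups here weakens binding beyond the scatter. Nothing available explains why the number rises.

Still open, going by these compounds, is whether one methoxy group alone would produce this step, and if so, which one. Also open, on these data alone, is whether a fluorine or a methyl on the phenyl would move the number in the same direction.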